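A few compounds are considered here, and "the series" means these few. Any claim that something is new, unique, unknown or untested is made for them only; others in the source may bear on it.

For the measured compounds named here, in a functional assay on COLO 205 cells (Homo sapiens) for inhibition, read by sulforhodamine B assay, with a stated time of 48 h, tested at 100 uM (a lower number here means a stronger effect, a higher number a weaker effect of the compound at the concentration tested), compound 2 `COc1cc(Cl)cc(-c2nn(-c3cccc(NC(=O)Nc4ccc(Cl)c(C(F)(F)F)c4)c3)cc2-c2ccncc2)c1` gives -79%, the lowest of the three numbers measured so far. Compound 1 `O=C(Nc1cccc(-n2cc(-c3ccncc3)c(-c3cc(O)cc(Cl)c3)n2)c1)Nc1ccc(Cl)c(C(F)(F)F)c1` gives -77%, within the scatter of compound 2, while compound 3 `COc1cc(Cl)cc(-c2nn(-c3cccc(NC(=O)Nc4cc(C(F)(F)F)cc(C(F)(F)F)c4)c3)cc2-c2ccncc2)c1` gives -68%, beyond it. Going by the values given here, the only measured step, a number 2 percentage points lower from compound 1 to compound 2 (within the scatter), changes a different part of the molecule. Compound 4 `COc1cc(Cl)cc(-c2nn(-c3cccc(NC(=O)c4cccc(C(F)(F)F)c4)c3)cc2-c2ccncc2)c1` differs from compound 2 by 3-(trifluoromethyl)phenyl in place of (4-chloro-3-(trifluoromethyl)phenyl)amino on a carbonyl carbon. Among the compounds with values here, no measured step touches this part, so the outcome rests on the change alone: the hydrogen-bond donor and the chlorine leave, and nothing replaces them. A weaker effect is expected, amounting to the step of a number 34 percentage points higher from compound 2 to compound 4 (beyond the scatter). Compound 4 is therefore estimated at -45%, somewhere between -80% and -5%.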

Compound 4, a percentage reported as activity, at one concentration (the size of the read-out at that concentration, not a potency): 45%
For compound 4 the middle estimate is 90 percentage points below the measured one; measured number above the stated range.
By their numbers in this assay, from the lowest: compounds 2, 1 and 3 (each within the scatter of the next, the first and the last beyond it); then compound 4.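

In this assay, the place on the carbonyl carbon responds far more strongly than the oxygen changed earlier, with a number 124 percentage points higher from compound 2 to compound 4 (beyond the scatter) set against a number 2 percentage points lower from compound 1 to compound 2 (within the scatter) for that earlier change. This single change removes the hydrogen-bond donor and the chlorine together, so their separate contributions cannot be told apart. Nothing available explains the size of this step. Still open, from the compounds shown here alone, is how a 4-chloro-3-(trifluoromethyl)phenyl placed directly on the carbonyl carbon would compare. Also open, going by these compounds, is how a methylamino link would behave in place of the amino link.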